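The source may hold more compounds than are shown below. What is called first, only, known or untested is meant among the compounds shown, and "the series" means these compounds.

Measured so far in a functional assay on NCI-H460 cells (Homo sapiens) for inhibition, read by sulforhodamine B assay, with a stated time of 48 h; on this read-out higher numbers stand for weaker inhibition of growth and lower numbers for stronger inhibition of growth:
Compound 1 `COc1cc(-c2nn(-c3cccc(NC(=O)Nc4cc(C(F)(F)F)cc(C(F)(F)F)c4)c3)cc2-c2ccncc2)ccc1Cl` gives 1870 nM in this assay.
Compound 2 `COc1cc(-c2nn(-c3cccc(NC(=O)Nc4ccc(Cl)c(Cl)c4)c3)cc2-c2ccncc2)ccc1Cl` reaches only a limit of this assay, > 50000 nM.
Compound 3 `O=C(Nc1cccc(-n2cc(-c3ccncc3)c(-c3ccc(Cl)c(O)c3)n2)c1)Nc1ccc(Cl)c(Cl)c1` gives 3570 nM in this assay.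

Compound 2 and compound 3 differ in one place, (hydrogen in place of methyl on an oxygen on an aromatic ring), and that change brings an at least 14-fold lower number from compound 2 to compound 3 (1.14 log units; beyond the scatter). The size of this step is only a bound, because the starting value is the limit of > 50000 nM in this assay, at which 1 of the 3 values shown sits. Compound 1 and compound 2 share their core in part, but the difference between the two cores is not broken down here; what the numbers show is that compound 1 and compound 3 sit within the usual scatter of each other.

The not yet measured compound 4 `O=C(Nc1cccc(-n2cc(-c3ccncc3)c(-c3ccc(Cl)c(O)c3)n2)c1)Nc1cc(C(F)(F)F)cc(C(F)(F)F)c1` stands to compound 1 as compound 3 stands to compound 2: the change is hydrogen in place of methyl on an oxygen on an aromatic ring, the same change at the same place. Since the earlier step in this assay was beyond the scatter, an improvement is expected for compound 4, though a smaller one, as compound 1 starts from a number rather than a limit. The step expected from compound 1 to compound 4 is a 2.3-fold lower number from compound 1 to compound 4 (0.37 log units; beyond the scatter). Compound 4 is therefore estimated at 800 nM in this assay, with a plausible span from 200 nM to 4000 nM.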

Compound 4, concentration for total growth inhibition: 1480 nM
Compound 4: middle estimate off by 1.9-fold (0.27 log units), on the low side; low and high end bracket the measured number.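

On the core of compound 1, the change from methoxy to hydroxy gives a 1.3-fold lower number from compound 1 to compound 4 (0.10 log units; within the scatter) in this assay, so the change has no effect on this core that can be told apart from the usual scatter. The change therefore does not carry over from one core to the other at the same size, and the two steps differ: the same change on two cores in this assay, an at least 14-fold lower number (1.14 log units; beyond the scatter) from compound 2 to compound 3 and a 1.3-fold lower number (0.10 log units; within the scatter) from compound 1 to compound 4, at least 11-fold (1.04 log units) apart, beyond the scatter of two such steps What these two pairs do not show is which feature of the cores sets the steps apart, nor how large the earlier step truly is, since it starts from a limit and not from a number: the limit of > 50000 nM in this assay, at which 1 of the 4 values shown sits.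

The compounds shown leave open how other groups at this place on the ring, such as an ethoxy group or an amine, would compare with the methoxy and hydroxy groups on either core. They also leave open which of the two steps a third core would follow.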